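Swapping the amine linker for an ether on the core

The source may hold more compounds than are shown below. What is called first, only, known or untested is meant among the compounds shown, and "the series" means these compounds.

All three measured compounds share one core and differ only in the group hung on the nitrogen attached to that core. Compound 1 `Nc1cc(N)c2nc(-c3ccccc3)c(NCc3ccc(Cl)c(Cl)c3)nc2c1` carries a 3,4-dichlorobenzyl group and gives 50100 nM in a functional assay on HCT-116 cells (Homo sapiens) for inhibition, read by sulforhodamine B assay, with a stated time of 48 h; a lower number here means that less compound is tolerated, a higher number that more compound is tolerated. Compound 3 `COc1ccc(CNc2nc3cc(N)cc(N)c3nc2-c2ccccc2)cc1` carries a 4-methoxybenzyl group and gives 52500 nM, so the step of a 1.0-fold higher number from compound 1 to compound 3 (0.02 log units; within the scatter) is one that does not rise above the usual noise of the measurement. Compound 2 `Nc1cc(N)c2nc(-c3ccccc3)c(NCc3ccc(F)cc3)nc2c1` carries a 4-fluorobenzyl group, and for compound 2 this assay reports only a limit, < 100000 nM, rather than a number. Because of that limit of < 100000 nM in this assay, at which 1 of the 3 values shown sits, the steps a step that the limit leaves unreadable from compound 1 to compound 2 and a step that the limit leaves unreadable from compound 2 to compound 3 cannot be given a size.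

Compound 4 `Nc1cc(N)c2nc(-c3ccccc3)c(Oc3ccc(F)cc3)nc2c1` has not yet been measured. It differs from compound 2 by 4-fluorophenoxy in place of (4-fluorobenzyl)amino on an aromatic carbon. Going by the values given here, none of the measured steps touches the linker; each of them only swaps the substituent on the benzyl ring, and the one readable step among them, a 1.0-fold higher number from compound 1 to compound 3 (0.02 log units; within the scatter), stayed inside the scatter. With no measured change of the linker to lean on, the expectation for compound 4 is a value close to the other three, estimated at 60000 nM with a range from 20000 nM to 150000 nM. The expected step that the limit leaves unreadable from compound 2 to compound 4 is therefore not one beyond the scatter, and a limit instead of a number is quite possible.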

Compound 4, concentration lethal to 50% of the cells: < 100000 nM
Compound 4 gave a limit, no number; the forecaster's own chance of this, stated with the estimate: 40%; the middle value is on the limit's open side.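

Compound 2 and compound 4 both give a limit rather than a number in this assay, so the step between them has no readable size: the limit of < 100000 nM in this assay, at which 2 of the 4 values shown sit.

The compounds shown leave open whether 4-fluorophenoxy in place of (4-fluorobenzyl)amino changes the value in this assay at all.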